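The source may report more compounds than this note shows. Statements on the series, on what has been measured and on what is new or still open speak of the compounds shown alone.

Measured in a functional assay on LNCaP cells (Homo sapiens) for cytotoxicity, read by MTT assay, with a stated time of 72 h; a lower number here means a stronger inhibitor, a higher number a weaker inhibitor:
- compound 1 `CC1=C(/C=C/C(=O)/C=C/c2cccc([N+](=O)[O-])c2)C(C)(C)CCC1`: 2700 nM
- compound 2 `CC1=C(/C=C/C(=O)/C=C/c2cc([N+](=O)[O-])ccc2Cl)C(C)(C)CCC1`: 4200 nM
- compound 3 `CC1=C(/C=C/C(=O)/C=C/c2cccc(C)c2)C(C)(C)CCC1`: 17800 nM

Compound 1 stands at the low end of these numbers. Compound 2 differs from it by chloro in place of hydrogen on an aromatic carbon, giving a 1.6-fold higher number from compound 1 to compound 2 (0.19 log units; within the scatter). Compound 3 carries methyl in place of nitro on an aromatic carbon, giving a 6.6-fold higher number from compound 1 to compound 3 (0.82 log units; beyond the scatter), a modest step.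

The next compound, compound 4 `CC1=C(/C=C/C(=O)/C=C/c2cccc([N+](=O)[O-])c2)C(C)(C)CCC1O`, changes a different part of the core of compound 1: hydroxy in place of hydrogen on a saturated ring carbon. For the measured compounds named here, both measured steps lie on the aromatic ring, and no measured compound carries a change on the saturated ring, so they offer only indirect guidance. They show that single changes in this series can range from nothing beyond the scatter to a modest shift. A modest rise in this assay is therefore expected, though it may not exceed the scatter. The expected step is a 1.7-fold higher number from compound 1 to compound 4 (0.22 log units; within the scatter). For compound 4 the estimate is 4500 nM, within an estimated range of 1500 nM to 13000 nM.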

Compound 4, half-maximal inhibitory concentration: 2000 nM
Beside the measured number, compound 4's estimate is 2.3-fold (0.35 log units) above it; the measured number falls inside the stated range.
By their numbers in this assay, from the lowest: compounds 4, 1 and 2 (each within the scatter of the next, the first and the last beyond it); then compound 3.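

In this assay, hydroxy in place of hydrogen on a saturated ring carbon, next to the ring atom that bears a methyl group, gives a 1.4-fold lower number from compound 1 to compound 4 (0.13 log units; within the scatter). For the compounds shown here, this is the first view of the saturated ring, and it shows that this carbon can carry hydroxy, with its hydrogen-bond donor and acceptor, without moving the number beyond the usual scatter of the assay, so the change is tolerated here rather than helpful or harmful. No data shown here bear on the reason for this result.

As far as these compounds go, whether an amine, a carboxylic acid or a longer chain on this same carbon would also leave the number within the scatter remains open. So does whether hydroxy here would give the same result alongside the chloro of compound 2 or the methyl of compound 3.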